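A few compounds are considered here, and "the series" means these few. Any claim that something is new, unique, unknown or untested is made for them only; others in the source may bear on it.

Of the compounds shown here, three with a shared core have been measured in a functional assay on DLD-1 cells (Homo sapiens) for antiproliferative activity, read by CellTiter-Glo, with a stated time of 72 h; on this read-out lower numbers stand for stronger inhibition and higher numbers for weaker inhibition. Compound 1 `COc1ccc(-c2cccc(S(=O)(=O)N3CCC(N4CCC(C)CC4)CC3)c2)cc1` gives 23 nM in this assay. Compound 2 `Cc1ccc(C#N)c(S(=O)(=O)N2CCC(N3CCC(C)CC3)CC2)c1` gives 285 nM, and compound 3 `Cc1cc(C)c(S(=O)(=O)N2CCC(N3CCCCCC3)CC2)c(C)c1` gives 5.3 nM. Among these three numbers compound 1 stands second highest: the nearest is compound 3, whose number is lower, and the furthest is compound 2, whose number is higher, and both gaps lie beyond the usual scatter.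

Compound 4 `CC1CCN(C2CCN(S(=O)(=O)c3cccc(Cl)c3)CC2)CC1` has not yet been measured. It differs from compound 1 in one place: chloro in place of 4-methoxyphenyl on an aromatic carbon, in words, chloro in place of 4-methoxyphenyl on an aromatic carbon. Within the data shown here, no pair of measured compounds shows this change on its own, so its effect cannot be read from the data. Compound 2, which also carries only small groups on that ring, gives 285 nM, whereas compound 3 gives 5.3 nM with small groups and a different amine, so small groups alone do not settle the outcome. The step of a 4.3-fold higher number from compound 1 to compound 4 (0.64 log units; beyond the scatter) is expected to raise the number beyond the scatter. Compound 4 is estimated at 100 nM, within a range from 25 nM to 400 nM.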

Compound 4, half-maximal inhibitory concentration: > 5000 nM
Compound 4: no number, only a limit; the forecaster's own chance of this, stated with the estimate: 5%; at least 50-fold (1.69 log units) between middle value and limit.
By their numbers in this assay, from the lowest: compound 3; then compound 1; then compound 2. At a limit, above all of these: compound 4.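

In this assay compound 4 gives > 5000 nM, which is a limit of the assay and not a number. Putting chloro in place of 4-methoxyphenyl on this aromatic carbon gives an at least 210-fold higher number from compound 1 to compound 4 (2.33 log units; beyond the scatter), the first single change seen in this set, and it shows that the activity of compound 1 depends strongly on what sits at this position. The size of this step rests on a limit rather than on two numbers: the limit of > 5000 nM in this assay, at which 1 of the 4 values shown sits.

The compounds shown leave open whether the whole 4-methoxyphenyl group is needed, since a plain phenyl, a methoxy group or a pyridyl group on this carbon would help to separate the part played by the ring from that of its methoxy group. Also open, on these data alone, is whether chloro at this position would behave the same way with the amine carried by compound 3.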